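Methyl to Hydrogen: What to Expect of Compound 3

The compounds below may be only part of what the source reports. "The series", "measured", "known", "first", "only" and "open" are said of these compounds alone.

Compound 1, `Cc1ccc(S(=O)(=O)NC(=O)Nc2ccc(Cl)cc2)cc1`: 106 ug/mL
Compound 2, `Cc1ccc(S(=O)(=O)N/C(=N\O)Nc2ccc(Cl)cc2)cc1`: 46 ug/mL

Going by the values given here, in a functional assay on TSGH 8302 cells (Homo sapiens) for cytotoxicity (on this read-out higher numbers stand for weaker inhibition and lower numbers for stronger inhibition), compound 2 gives the lower of the two numbers so far, and compound 1 lies beyond the scatter above it. Compound 3, `O=S(=O)(N/C(=N\O)Nc1ccc(Cl)cc1)c1ccccc1`, differs from compound 2 in one place: hydrogen in place of methyl on an aromatic carbon. Among the compounds with values here, no measured pair shows this change, so nothing in the data fixes its size. The step of a 1.2-fold higher number from compound 2 to compound 3 (0.08 log units; within the scatter) is expected to stay within the scatter, if anything toward a slightly higher number. Compound 3 is therefore estimated at 55 ug/mL, with a range from 25 ug/mL to 120 ug/mL.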

Compound 3, half-maximal inhibitory concentration: 52 ug/mL
Compound 3: middle estimate off by 1.1-fold (0.02 log units), on the high side, and the stated range covers the measured number.
By their numbers in this assay, from the lowest: compounds 2 and 3 (each within the scatter of the next); then compound 1.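

In this assay, going by these compounds alone, this is the first measured pair for the change at this position, and it gives a 1.1-fold higher number from compound 2 to compound 3 (0.05 log units; within the scatter) as the step for hydrogen in place of methyl. The methyl group on the aromatic carbon is therefore not needed to keep the number of compound 2 in this assay. No measurement here offers an explanation for this result.

Going by these compounds, whether a larger group at this place, such as methoxy, an amine or a carboxylic acid, would move the number beyond the scatter remains open. Also open, on these data alone, is whether the same change would read alike on the core of compound 1.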